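A Shorter Amide Chain on the Shared Core

The source may hold more compounds than are shown below. What is called first, only, known or untested is meant among the compounds shown, and "the series" means these compounds.

Compound 1, `C=CC1=C(C(=O)NCCC)C(c2ccc(F)cc2)OC1`, in a functional assay on QGY7701 cells (Homo sapiens) for cytotoxicity, read by MTT assay, with a stated time of 24 h (a higher number here means a weaker inhibitor, a lower number a stronger inhibitor), gives > 100000 nM, which is a limit of the assay and not a number.
Compound 2, `C=CC1=C(C(=O)NCc2ccccc2)C(c2ccc(OC)cc2)OC1`, in this assay gives > 100000 nM, again a limit of the assay.
Compound 3, `C=CC1=C(C(=O)NCCCCC)C(c2ccc(Cl)c(Cl)c2)OC1`, in this assay gives > 100000 nM, once more a limit of the assay.

All three compounds carry the same core with an amide and differ only in the group on the amide nitrogen and in the substituents on the aryl ring. Within the data shown here, none of them reaches a measurable value: compound 3 stands at the limit of > 100000 nM in this assay, at which 3 of the 3 values shown sit, and no compound in this set is separated from any other by a step that can be sized. Among the measured compounds shown here, no step between measured compounds is therefore available to show how a change on the amide chain moves the read-out.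

Compound 4, `C=CC1=C(C(=O)NCCC)C(c2ccc(Cl)c(Cl)c2)OC1`, has not yet been measured. It differs from compound 3 by hydrogen in place of ethyl on a saturated chain carbon, three bonds along the chain from an amide-type nitrogen. The step from compound 3 to compound 4 is expected to be a step that the limit leaves unreadable from compound 3 to compound 4, that is, no shift beyond the usual scatter, since the measured compounds give no sign that the amide chain length matters here. Compound 4 is therefore estimated at 150000 nM, within a range of 50000 nM to 500000 nM, and it will most likely again be reported only as a limit.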

Compound 4, half-maximal inhibitory concentration: 31300 nM
The estimate for compound 4 lay 4.8-fold (0.68 log units) above the measured number; measured number below the stated range.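

In this assay, among these compounds, taking the amide chain from pentyl to propyl gives an at least 3.1-fold lower number from compound 3 to compound 4 (0.50 log units; beyond the scatter), so this chain can move the read-out, which the earlier compounds, all sitting at one limit, could not show. Among the compounds shown here, compound 4 is the first compound here to give an actual number rather than a limit, and within this single pair the shorter chain goes with the stronger inhibitor. The true size of the step stays unknown, because only a minimum can be stated when the starting compound has no number of its own: the limit of > 100000 nM in this assay, at which 3 of the 4 values shown sit.

Compound 1 also carries the propyl chain, with a different substituent pattern on the aryl ring, and gives > 100000 nM, which is a limit, so it goes against any reading that propyl alone is enough, and the aryl substituents may matter as well. Whether an ethyl or butyl chain, or a chain ending in an amine or a carboxylic acid, would lower the number further or raise it again is left open by the compounds shown.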